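Bromo Placed on the Phenyl Ring: Compound 2 to Compound 4

This account rests on a few compounds, and the source may have more. Where it says the series, first, only, none or still open, it means among the compounds named here.

Compound 1, `OC(CCn1nc2c(Br)c(Br)c(Br)c(Br)c2n1)c1ccc(Br)cc1`, in a functional assay on MCF7 cells (Homo sapiens) for antiproliferative activity, read by MTT assay, with a stated time of 48 h, tested at 50 uM; a higher number here means a weaker effect of the compound at the concentration tested, a lower number a stronger effect: 15%
Compound 2, `OC(CCn1nc2c(Br)c(Br)c(Br)c(Br)c2n1)c1ccccc1`, in this assay: 23%
Compound 3, `C[C@@H](O)CCn1nc2c(Br)c(Br)c(Br)c(Br)c2n1`, in this assay: 64%

Among the three numbers, compound 2 holds the second highest place. Going by the values given here, its nearest neighbour is compound 1, and the only measured step that touches the phenyl ring runs between them: a number 8 percentage points higher from compound 1 to compound 2 (within the scatter), a change of hydrogen in place of bromo on an aromatic carbon that stays within the scatter. Among the compounds with values here, the furthest number belongs to compound 3, which gives 64% and carries no phenyl ring at all, so it offers no step that bears on a bromo move.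

Compound 4, `OC(CCn1nc2c(Br)c(Br)c(Br)c(Br)c2n1)c1cccc(Br)c1`, is the compound not yet measured. Relative to compound 2 the difference is bromo in place of hydrogen on an aromatic carbon, or phenyl to 3-bromophenyl when cut one bond further out. Within the data shown here, the one relevant step, from compound 1 to compound 2, shows that removing a bromo from this ring made no change beyond the scatter; putting one back at another aromatic carbon is therefore expected to move the number little. Compound 4 is expected to sit near compound 2 and compound 1, with the estimated step being a number 4 percentage points lower from compound 2 to compound 4 (within the scatter). The estimate for compound 4 in this assay is 19%, within a range from 8% to 35%.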

Compound 4, a percentage reported as activity, at one concentration (the size of the read-out at that concentration, not a potency): 11%
For compound 4 the middle estimate is 8 percentage points above the measured one, and the stated range covers the measured number.
By their numbers in this assay, from the lowest: compounds 4, 1 and 2 (each within the scatter of the next, the first and the last beyond it); then compound 3.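

In this assay, going by these compounds alone, the change at this ring carbon gives a number 12 percentage points lower from compound 2 to compound 4 (beyond the scatter), a modest shift, but the first step on the phenyl ring that lies beyond the scatter, so a bromo on the ring can matter to the read-out when it stands meta to the large group. The comparison of the two bromo isomers gives a number 4 percentage points lower from compound 1 to compound 4 (within the scatter), which lies within the scatter, so the 3-bromophenyl and 4-bromophenyl compounds cannot be told apart here, and the data do not establish a preference for one ring position. No supporting measurement is available to explain the effect of the added bromo.

The compounds shown leave open whether this step belongs to bromo itself or would also appear with a chloro, methoxy or amine group on the same aromatic carbon. They also leave open what a carbonyl or an amine in place of the chain hydroxyl would do to the number for compound 4.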